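This account rests on a few compounds, and the source may have more. Where it says the series, first, only, none or still open, it means among the compounds named here.

Measured in a toxicity assay on THP-1 cells (Homo sapiens) for cytotoxicity, read by luminescence and CellTiter-Glo, with a stated time of 72 h (on this read-out lower numbers stand for higher toxicity in this test and higher numbers for lower toxicity in this test), so far
- compound 1 `CN1CCN(c2ccc(Nc3nccc(-c4ccc5ccccc5c4)n3)cc2C(F)(F)F)CC1` gives 3040 nM
- compound 2 `CN1CCN(c2ccc(Nc3nccc(-c4cccc([N+](=O)[O-])c4)n3)cc2C(F)(F)F)CC1` gives 3890 nM

Within the data shown here, the value of compound 2 stands level with its only neighbour, the one measured step being a 1.3-fold higher number from compound 1 to compound 2 (0.11 log units; within the scatter) and no more. Compound 3 `CN1CCN(c2ccc(Nc3nccc(-c4cnn5ncccc45)n3)cc2C(F)(F)F)CC1` brings a group of 9 heavy atoms (6 carbon, 3 nitrogen; one five-membered aromatic ring with 2 hetero atoms, one six-membered aromatic ring with 2 hetero atoms) in place of a group of 9 heavy atoms (6 carbon, 1 nitrogen, 2 oxygen; one six-membered aromatic ring of carbon only), on an aromatic carbon on an aromatic carbon. Among the measured compounds shown here, the measured step also exchanged the group on that carbon, so it is the only guide, and thin support. In this assay no change beyond the scatter is expected. The estimated step is a 1.1-fold lower number from compound 2 to compound 3 (0.05 log units; within the scatter) on this evidence. Compound 3 is expected at 3500 nM with a range of 1300 nM to 10000 nM for now.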

Compound 3, half-maximal cytotoxic concentration: < 50 nM
Compound 3 was reported as a limit (the forecaster's own chance of this, stated with the estimate: 10%); middle value at least 70-fold (1.84 log units) away from the limit.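

In this assay, the position opposite the ring nitrogen no longer looks indifferent to its group. Exchanging naphthalen-2-yl for 3-nitrophenyl stayed within the scatter, but the group with a five-membered and a six-membered aromatic ring, each with 2 hetero atoms, gives an at least 77-fold lower number from compound 2 to compound 3 (1.89 log units; beyond the scatter) and an at least 60-fold lower number from compound 1 to compound 3 (1.78 log units; beyond the scatter). Compound 3 is reported only as a limit: the limit of < 50 nM in this assay, at which 1 of the 3 values shown sits.

On these data alone, how far the number falls beyond that limit remains open, as does which feature of the entering group carries the step. A single pyridine ring or a simple amine on the same carbon would help separate these possibilities.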